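Removing One Trifluoromethyl Group: Compound 2 to Compound 3

A few compounds are considered here, and "the series" means these few. Any claim that something is new, unique, unknown or untested is made for them only; others in the source may bear on it.

Two measured compounds share the same core and differ only in the aryl-bearing end. Compound 1 `COc1cc(Cl)cc(-c2nn(-c3cccc(NC(=O)c4ccc(Cl)c(Cl)c4)c3)cc2-c2ccncc2)c1` in a functional assay on SNB-75 cells (Homo sapiens) for inhibition, read by sulforhodamine B assay, with a stated time of 48 h, tested at 10 uM (on this read-out lower numbers stand for a stronger effect and higher numbers for a weaker effect at the one concentration tested), gives 50.6%. Compound 2 `COc1cc(Cl)cc(-c2nn(-c3cccc(NC(=O)Nc4cc(C(F)(F)F)cc(C(F)(F)F)c4)c3)cc2-c2ccncc2)c1` in this assay gives 11.3%, the lowest of the two numbers and a value that sits beyond the scatter from compound 1.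

The unmeasured compound 3 `COc1cc(Cl)cc(-c2nn(-c3cccc(NC(=O)Nc4cccc(C(F)(F)F)c4)c3)cc2-c2ccncc2)c1` is derived from compound 2 by a single change: hydrogen in place of trifluoromethyl on an aromatic carbon. Going by the values given here, no pair of measured compounds traces this change, so its size must be estimated. Because compound 2 already stands at 11.3%, the loss of one of its two trifluoromethyl groups is expected to cost some of that effect, and the expected step in this assay is a number 18.7 percentage points higher from compound 2 to compound 3 (beyond the scatter), toward a weaker effect and beyond the scatter. Compound 3 is therefore estimated to give 30% in this assay, within a range of 12% to 55%.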

Compound 3, a percentage reported as activity, at one concentration (the size of the read-out at that concentration, not a potency): 12.5%
Compound 3: middle estimate off by 17.5 percentage points, on the high side; low and high end bracket the measured number.
By their numbers in this assay, from the lowest: compounds 2 and 3 (each within the scatter of the next); then compound 1.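

In this assay, hydrogen in place of trifluoromethyl on this aromatic carbon gives a number 1.2 percentage points higher from compound 2 to compound 3 (within the scatter), so at this position the second trifluoromethyl group is not needed to keep the read-out at the level of compound 2. Going by these compounds alone, the large step between the end groups therefore does not depend on that second group: (3-(trifluoromethyl)phenyl)amino in place of 3,4-dichlorophenyl on a carbonyl carbon gives a number 38.1 percentage points lower from compound 1 to compound 3 (beyond the scatter), with only one trifluoromethyl group present. Nothing available here explains either step.

The compounds shown leave open whether the remaining trifluoromethyl group matters at all, or whether a chlorine, a methoxy group or a nitrile on that carbon would serve as well. With a single tested concentration, they also leave open whether compound 2 and compound 3 would still match at lower concentrations.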